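Acetyl in place of phenoxy: compound 3 to compound 4

The source may hold more compounds than are shown below. What is called first, only, known or untested is meant among the compounds shown, and "the series" means these compounds.

Compound 3 `O=c1cc(Oc2ccccc2)c2ccc(OCc3cccc(Cl)c3)cc2o1` gives 4070 nM in an assay on isolated protein (strain Sprague-Dawley) for inhibition of Amine oxidase [flavin-containing] B (Rattus norvegicus), read by spectrophotometry, with a stated time of 5 min (a lower number here means a stronger inhibitor, a higher number a weaker inhibitor), the second highest of the three numbers measured. For the measured compounds named here, its nearest neighbour is compound 1 `CC(C)Oc1cc(=O)oc2cc(OCc3cccc(Cl)c3)ccc12` with 24500 nM; the step of a 6.0-fold lower number from compound 1 to compound 3 (0.78 log units; beyond the scatter) is the only single-place change among the measured compounds. Compound 2 `NC(=O)COc1cc(=O)oc2cc(OCc3cccc(Br)c3)ccc12` stands furthest away with 8.91 nM. Compound 4 `CC(=O)c1cc(=O)oc2cc(OCc3cccc(Cl)c3)ccc12` differs from compound 3 by acetyl in place of phenoxy on an aromatic carbon. Going by the values given here, only the step from compound 1 to compound 3 touches the same position, and it shows a modest move when phenyl replaces isopropyl on the oxygen; no measured step removes that oxygen or introduces an acetyl, so the direction for compound 4 is open. For compound 4 a step of a 2.0-fold higher number from compound 3 to compound 4 (0.29 log units; within the scatter) is expected, since compound 1 gives 24500 nM with isopropyl rather than phenyl at this place. Compound 4 is estimated at 8000 nM, with a range of 1000 nM to 60000 nM.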

Compound 4, half-maximal inhibitory concentration: 39.8 nM
Compound 4: middle estimate off by 200-fold (2.30 log units), on the high side, outside the stated range (below it).
By their numbers in this assay, from the lowest: compound 2; then compound 4; then compound 3; then compound 1.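

Acetyl at this place, opposite the ring oxygen, changes far more than swapping one oxygen-linked group for another: in this assay replacing phenoxy gives a 100-fold lower number from compound 3 to compound 4 (2.01 log units; beyond the scatter), and replacing isopropoxy gives a 620-fold lower number from compound 1 to compound 4 (2.79 log units; beyond the scatter). Both steps are large, whereas the change from isopropoxy to phenoxy gave only a 6.0-fold lower number from compound 1 to compound 3 (0.78 log units; beyond the scatter). No measurement on hand accounts for this difference.

The compounds shown leave open whether the carbonyl or the loss of the linking oxygen drives the step. An ethyl group, a methyl ester or a carboxylic acid at this place would separate these readings.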